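Solubility notes: hydrogen for methyl, compound 3 to compound 4

The source may report more compounds than this note shows. Statements on the series, on what has been measured and on what is new or still open speak of the compounds shown alone.

Compound 3 `Cn1ncc2c(NC3(c4ccc(C(F)(F)F)cc4)CC3)nc(Cl)nc21` gives 156000 nM in a physicochemical assay for solubility, at pH 6.5; on this read-out higher numbers stand for higher solubility and lower numbers for lower solubility. It sits second of the three measured numbers: compound 1 `Cn1ncc2c(NC3(c4ccc(C(F)(F)F)cc4)CC3)nc(O)nc21` gives 175000 nM and compound 2 `Cn1ncc2c(NCc3cccc(Cl)c3)nc(Cl)nc21` gives 78000 nM, both within the scatter of compound 3. For the measured compounds named here, the only single-point step measured, a 1.1-fold lower number from compound 1 to compound 3 (0.05 log units; within the scatter), concerns an aromatic carbon substituent and does not bear on the present change. Compound 4 `FC(F)(F)c1ccc(C2(Nc3nc(Cl)nc4[nH]ncc34)CC2)cc1` differs from compound 3 by hydrogen in place of methyl on an aromatic nitrogen. Going by the values given here, no measured step addresses this change, so no direction beyond the scatter can be supported. Compound 4 is therefore expected to lie near compound 3, at an estimated 110000 nM (range 35000 nM to 300000 nM), an expected step of a 1.4-fold lower number from compound 3 to compound 4 (0.15 log units; within the scatter).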

Compound 4, solubility: 105000 nM
Beside the measured number, compound 4's estimate is 1.0-fold (0.02 log units) above it; measured number inside the range.
By their numbers in this assay, from the lowest: compounds 2, 4, 3 and 1 (each within the scatter of the next, the first and the last beyond it).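

In this assay, for the compounds shown here, hydrogen in place of methyl on an aromatic nitrogen of the five-membered ring gives the first measured step at this position (a 1.5-fold lower number from compound 3 to compound 4 (0.17 log units; within the scatter)). For this pair, the change stays within the scatter, so the methyl is not required for the number to remain in the range of compound 3. No available measurement accounts for this step.

From the compounds shown here alone, whether the same change behaves alike with the substituents of compound 1 or compound 2 remains open. Also open, going by these compounds, is how an ethyl group, a longer chain or a chain ending in an amine would read on this nitrogen.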